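This account rests on a few compounds, and the source may have more. Where it says the series, first, only, none or still open, it means among the compounds named here.

In a functional assay on HeLa cells (Homo sapiens) for cytotoxicity, read by MTT assay, with a stated time of 24 h (on this read-out higher numbers stand for weaker inhibition and lower numbers for stronger inhibition), three compounds have been measured so far:

Compound 1 `COc1ccc(/C=C2\SC(=O)N(Cc3ccc(C(=O)O)cc3)C2=O)cc1`: 40000 nM
Compound 2 `O=C(O)c1ccc(CN2C(=O)S/C(=C\c3ccccn3)C2=O)cc1`: 62000 nM
Compound 3 `O=C(O)c1ccc(CN2C(=O)S/C(=C\c3ccc(F)cc3)C2=O)cc1`: 34000 nM

Compound 1 holds the second highest of these three numbers. Its nearest neighbour is compound 3, with a 1.2-fold lower number from compound 1 to compound 3 (0.07 log units; within the scatter), and its furthest is compound 2, with a 1.6-fold higher number from compound 1 to compound 2 (0.19 log units; within the scatter). The remaining pair gives a 1.8-fold lower number from compound 2 to compound 3 (0.26 log units; within the scatter). All three compounds share one core and differ only in the group attached to the double-bonded chain carbon bound to a double-bonded ring carbon, and none of these exchanges moved the number beyond the scatter.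

Compound 4 `O=C(O)c1ccc(CN2C(=O)S/C(=C\c3ccco3)C2=O)cc1` carries a further variation at the same place: furan-2-yl in place of 4-methoxyphenyl on a double-bonded chain carbon bound to a double-bonded ring carbon. Within the data shown here, the steps that bear on this change are those from compound 1 to compound 2 and from compound 2 to compound 3, since both exchange the group at this position, and both stayed within the scatter. A step of similar size is therefore expected here, that is, a 1.1-fold higher number from compound 1 to compound 4 (0.02 log units; within the scatter), with no clear direction. Compound 4 is thus estimated to give 42000 nM in this assay, within a range of 20000 nM to 90000 nM.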

Compound 4, half-maximal inhibitory concentration: 80000 nM
Compound 4: middle estimate off by 1.9-fold (0.28 log units), on the low side, within the range that was stated.
By their numbers in this assay, from the lowest: compounds 3, 1, 2 and 4 (each within the scatter of the next, the first and the last beyond it).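

Among these compounds, exchanging 4-fluorophenyl for furan-2-yl gives the first step at this place that passes the scatter in this assay (a 2.4-fold higher number from compound 3 to compound 4 (0.37 log units; beyond the scatter)), though only a modest one. Against the other two groups, furan-2-yl stays within the scatter (a 2.0-fold higher number from compound 1 to compound 4 (0.30 log units; within the scatter); a 1.3-fold higher number from compound 2 to compound 4 (0.11 log units; within the scatter)), so among these four aromatic rings only this one pair separates, and the range of numbers at this place remains narrow. Why this pair separates cannot be said from the data available.

From the compounds shown here alone, all four groups at this place are aromatic rings, so what an amine, a hydroxyl or a longer alkyl chain would do there stays open. The carboxylic acid is common to all four compounds, which leaves open what an ester in its place would do.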